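Swapping Benzyl for Acetyl on the Shared Core

A few compounds are considered here, and "the series" means these few. Any claim that something is new, unique, unknown or untested is made for them only; others in the source may bear on it.

Within the data shown here, compound 1 `C=CCn1c(=S)n(C2OC(COCc3ccccc3)[C@H]3OC(C)(C)O[C@@H]23)c2nc(N)nc(O)c21` gives 47 uM in a functional assay (B cells) with Mus musculus as the target (a lower number here means that less compound is needed, a higher number that more compound is needed for the effect), and stands lowest of the two numbers known so far; compound 2 `COc1ccc(Cn2c(=O)n(C3OC(CO)[C@@H](O)[C@H]3O)c3nc(N)nc(O)c32)cc1` gives 135 uM in this assay, a gap beyond the scatter, though the two structures differ in several places and no single-change step is recorded. Compound 3 `C=CCn1c(=S)n(C2OC(COC(C)=O)[C@H]3OC(C)(C)O[C@@H]23)c2nc(N)nc(O)c21` remains unmeasured and differs from compound 1 by acetyl in place of benzyl on an oxygen on a saturated carbon and nothing else. Without a comparable step to lean on, one expects only a small shift, probably a slight rise within the scatter: a 1.5-fold higher number from compound 1 to compound 3 (0.17 log units; within the scatter) is the estimate. Compound 3 is therefore estimated at 70 uM (range 25 uM to 200 uM).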

Compound 3, concentration for half-maximal effect: 50 uM
Beside the measured number, compound 3's estimate is 1.4-fold (0.15 log units) above it, within the range that was stated.
By their numbers in this assay, from the lowest: compounds 1 and 3 (each within the scatter of the next); then compound 2.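

Among these compounds, the first single-change step at this position, in this assay, reads a 1.1-fold higher number from compound 1 to compound 3 (0.03 log units; within the scatter) and so does not separate acetyl from benzyl on this oxygen. On the shared core, the six-membered aromatic ring of benzyl can therefore give way to the smaller acetyl group with the number staying within the scatter. No measurement shown here offers an explanation for this result.

Going by these compounds, whether a free hydroxyl, an amine, a carboxylic acid or a longer chain on this oxygen would read the same remains open. So does whether the same swap would hold on the core of compound 2.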